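This account rests on a few compounds, and the source may have more. Where it says the series, first, only, none or still open, it means among the compounds named here.

Compound 1, `C/C(=C\c1cc(-c2ccccc2)co1)C(N)=O`, in an ADME assay on NIH3T3 cells (Mus musculus) for cytotoxicity, read by CCK-8 assay, with a stated time of 24 h; a higher number here means a weaker inhibitor, a lower number a stronger inhibitor: compound 1 gives > 50000 nM, a limit of the assay and not a number.
Compound 2, `C/C(=C\c1cc(-c2ccc(C)cc2)co1)C(N)=O`: compound 2 gives > 50000 nM, again a limit.
Compound 3, `C/C(=C\c1cc(-c2ccccc2)cs1)C(N)=O`: compound 3 gives > 50000 nM, again a limit.

The unmeasured compound is compound 4, `C/C(=C\c1cc(-c2ccc(C)cc2)cs1)C(N)=O`. It arises from compound 3 by methyl in place of hydrogen on an aromatic carbon. The same change has been made once before among these compounds, from compound 1 to compound 2, where it is methyl in place of hydrogen on an aromatic carbon; the two place descriptions agree word for word, so it is the same change. The cores of compound 1 and compound 3 differ, but the difference between the two cores is not broken down here.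

What that earlier change did in this assay cannot be read: the step that the two limits leave unreadable from compound 1 to compound 2 sits between two limits, and so its size is not known. All that the three measured values show is stated in the limit of > 50000 nM in this assay, at which 3 of the 3 values shown sit.

Going by the values given here, for compound 4 the same limit is expected, as both compound 1 and compound 3 stand at the limit and the only earlier instance of the change left compound 2 there as well. The step from compound 3 to compound 4 is therefore estimated to be about a step that the limit leaves unreadable from compound 3 to compound 4, with the understanding that an unreadable step cannot be measured in this way. The estimate for compound 4 is 60000 nM, most likely reported as a limit rather than a number, with a plausible span from 30000 nM to 150000 nM.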

Compound 4, half-maximal inhibitory concentration: > 50000 nM
Compound 4: only a limit was reported; the forecaster's own chance of this, stated with the estimate: 85%; the middle value lies beyond the limit too.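

In this assay compound 4 gives > 50000 nM as a limit of the assay and not a number. Going by these compounds alone, compound 3 also stands at a limit, so the step between compound 3 and compound 4 cannot be read, and no new step emerges. The compounds shown leave open whether methyl in place of hydrogen on an aromatic carbon changes the read-out at all, since every value sits at one limit: the limit of > 50000 nM in this assay, at which 4 of the 4 values shown sit.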